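From a fluorinated to a brominated benzyl on a nucleoside

The source may report more compounds than this note shows. Statements on the series, on what has been measured and on what is new or still open speak of the compounds shown alone.

The study concerns a shared nucleoside core carrying a benzylamino group. Compound 1, `OC[C@H]1O[C@@H](n2cnc3c(NCc4ccccc4F)ncnc32)[C@H](O)[C@@H]1O`, carries a fluorine on the benzyl ring. In a functional assay on B16 cells (Mus musculus) for antiproliferative activity, with a stated time of 72 h (on this read-out higher numbers stand for weaker inhibition and lower numbers for stronger inhibition), compound 1 gives > 166000 nM, which is a limit of the assay rather than a number. Compound 2, `OC[C@H]1O[C@@H](n2cnc3c(NCc4cccc(F)c4)ncnc32)[C@H](O)[C@@H]1O`, carries its fluorine as a 3-fluorobenzyl group. In this assay compound 2 gives "not determined" (no result reported), so no result is reported for it. Compound 2 therefore stands without a number of its own, and the only figure shown among the two values is the limit of > 166000 nM in this assay, at which 1 of the 2 values shown sits. Compound 3, `OC[C@H]1O[C@@H](n2cnc3c(NCc4cccc(Br)c4)ncnc32)[C@H](O)[C@@H]1O`, is the next member. It differs from compound 2 by bromo in place of fluoro on an aromatic carbon, turning the 3-fluorobenzyl group into a 3-bromobenzyl group. For the measured compounds named here, with no measured step between any two compounds, the author expects no shift beyond the scatter and, given the limit seen for compound 1, expects compound 3 to fall at about 120000 nM, within a range of 20000 nM to 400000 nM.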

Compound 3, half-maximal inhibitory concentration: > 166000 nM
Compound 3 gave a limit, no number; the forecaster's own chance of this, stated with the estimate: 60%; at least 1.3-fold (0.14 log units) between middle value and limit.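

Compound 3, like compound 1, sits at a limit in this assay rather than at a number, and compound 2 offers no number, so no step can be read among these compounds. As far as these compounds go, whether bromo in place of fluoro changes the inhibition of these cells stays open.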